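A few compounds are considered here, and "the series" means these few. Any claim that something is new, unique, unknown or untested is made for them only; others in the source may bear on it.

Among the measured compounds shown here, compound 1 `COc1cc2c(cc1OC)C(CC(=O)Nc1ccc(Cl)cc1)CC2` stands highest of the two compounds measured so far in a functional assay on the whole organism (strain Wistar) for inhibition, with Rattus norvegicus as the target, read by paw edema, with a stated time of 1 h, at a dose of 100 mg/kg (on this read-out higher numbers stand for more inhibition at the one dose given (going by the name of the read-out) and lower numbers for less inhibition), where compound 1 gives 71.9%. For the measured compounds named here, its only measured neighbour is compound 2 `COc1cc2c(cc1OC)C(CC(=O)Nc1ccc([N+](=O)[O-])cc1)CC2`, which in this assay gives 37.5%; the single measured step, a number 34.4 percentage points lower from compound 1 to compound 2 (beyond the scatter), shows that a change on the aromatic ring attached to the amide nitrogen can move the read-out far beyond the scatter. The next compound, compound 3 `COc1cc2c(cc1OC)C(CC(=O)Nc1ccncc1)CC2`, differs from compound 1 by pyridin-4-yl in place of 4-chlorophenyl on an amide-type nitrogen. Going by the values given here, no measured step covers this exact change; the step from compound 1 to compound 2 bears on it only in that both alter the group on the amide nitrogen, and there the change cost a large amount. With the 4-chlorophenyl of the best compound removed altogether, a downward step in this assay is expected, though of uncertain size: the estimated step is a number 26.9 percentage points lower from compound 1 to compound 3 (beyond the scatter). Compound 3 is therefore expected to give about 45% in this assay, with a likely range from 20% to 70%.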

Compound 3, a percentage reported as inhibition, in the whole organism at one dose (the size of the read-out at that dose, not a potency): 42.2%
Estimate against measurement, compound 3: 2.8 percentage points above, and the stated range covers the measured number.
By their numbers in this assay, from the lowest: compounds 2 and 3 (each within the scatter of the next); then compound 1.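

In this assay, pyridin-4-yl in place of 4-chlorophenyl on the amide-type nitrogen gives a number 29.7 percentage points lower from compound 1 to compound 3 (beyond the scatter), so the loss at this position is not tied to the nitro group and also follows a change of the ring itself. Compound 3 gives 42.2% and compound 2 gives 37.5%, two values within the scatter of each other, so these two quite different replacements end up at one level, and both stay clearly short of compound 1 with its 4-chlorophenyl. Nothing in the data given explains this loss at the position.

The compounds shown leave open whether the chloro group itself matters or whether the benzene ring carrying it is enough, which a plain phenyl, or a 4-fluorophenyl or 4-methylphenyl, on the same nitrogen would begin to separate. They also leave open whether a benzyl group, with its extra carbon between the amide nitrogen and the ring, or a pyridin-3-yl in place of the pyridin-4-yl would hold the read-out nearer to compound 1 or at the level of compound 3.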